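Replacing 4-(hydroxymethyl)piperidin-1-yl with 4-methylpiperazin-1-yl

The source may hold more compounds than are shown below. What is called first, only, known or untested is meant among the compounds shown, and "the series" means these compounds.

In a functional assay on HepG2 cells (Homo sapiens) for antiproliferative activity, read by MTT assay, with a stated time of 72 h (a lower number here means a stronger inhibitor, a higher number a weaker inhibitor), compound 3 (`COc1cc2c(Nc3ccc(C#N)cc3)ncnc2cc1OCCCN1CCC(CO)CC1`) gives 61800 nM and lies within the scatter of both other measured compounds. Compound 2 (`COc1cc2c(Nc3ccc(C#N)cc3)ncnc2cc1OCCCN1CCC(O)CC1`) gives 67900 nM and compound 1 (`COc1cc2c(Nc3ccc(C#N)cc3)ncnc2cc1OCCCN1CCC(C)CC1`) gives 32100 nM in the same read-out. The unmeasured compound 4 (`COc1cc2c(Nc3ccc(C#N)cc3)ncnc2cc1OCCCN1CCN(C)CC1`) differs from compound 3 in one place: 4-methylpiperazin-1-yl in place of 4-(hydroxymethyl)piperidin-1-yl on a saturated chain carbon, three bonds along the chain from an oxygen on an aromatic ring.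

The measured steps all change only the group on a saturated ring carbon, and they are small. The largest is modest (a 2.1-fold higher number from compound 1 to compound 2 (0.33 log units; beyond the scatter)), while the other two stay within the scatter (a 1.9-fold higher number from compound 1 to compound 3 (0.28 log units; within the scatter); a 1.1-fold lower number from compound 2 to compound 3 (0.04 log units; within the scatter)). None of them replaces the six-membered non-aromatic ring itself, so the data hold no direct measure of this change. Compound 4 does carry a methyl group, as compound 1 does, and the step to compound 3 from that compound stays small (a 1.9-fold higher number from compound 1 to compound 3 (0.28 log units; within the scatter)). No step beyond the scatter is therefore expected in this assay, and any shift is expected to be towards a slightly lower number. The estimated step is small (a 1.4-fold lower number from compound 3 to compound 4 (0.14 log units; within the scatter)). For compound 4 the estimated value is 45000 nM (expected range 18000 nM to 95000 nM).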

Compound 4, half-maximal inhibitory concentration: 13800 nM
Compound 4: the middle estimate sits 3.3-fold (0.51 log units) above what was measured; the measured number lies below the stated range.
By their numbers in this assay, from the lowest: compound 4; then compounds 1, 3 and 2 (each within the scatter of the next, the first and the last beyond it).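

In this assay, going by these compounds alone, the ring at the end of the 3-(4-methylpiperazin-1-yl)propyl chain proves to be a more sensitive point than the group on a saturated ring carbon, which had produced only small steps among the earlier compounds. Exchanging either hydroxylated piperidine for 4-methylpiperazin-1-yl moves the number beyond the scatter (a 4.5-fold lower number from compound 3 to compound 4 (0.65 log units; beyond the scatter); a 4.9-fold lower number from compound 2 to compound 4 (0.69 log units; beyond the scatter)), and the shift persists when the methyl group is retained, as 4-methylpiperazin-1-yl replaces 4-methylpiperidin-1-yl (a 2.3-fold lower number from compound 1 to compound 4 (0.37 log units; beyond the scatter)), so the loss of the hydroxy group does not account for the whole change and compound 4 is the most potent of the four. No measured evidence is available to explain this shift.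

As far as these compounds go, it remains open whether the lower number depends on the methyl group on the second ring nitrogen, which piperazin-1-yl or 4-acetylpiperazin-1-yl would test, or on that nitrogen itself, which morpholin-4-yl would test. The compounds shown also leave open whether the 4-methylpiperazin-1-yl advantage would hold on a shorter ethyl or a longer butyl chain.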